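Cyclohexyloxy for cyclohexylamino: expected cytotoxicity of compound 4

The compounds below may be only part of what the source reports. "The series", "measured", "known", "first", "only" and "open" are said of these compounds alone.

Measured so far in an ADME assay on MT4 cells (Homo sapiens) for cytotoxicity, read by MTT assay; a lower number here means that less compound is tolerated, a higher number that more compound is tolerated:
compound 1 `Cc1cnc(Nc2ccc(C#N)cc2)nc1OC1CCCCC1`, 31200 nM
compound 2 `N#Cc1ccc(Nc2nccc(SC3CCCCC3)n2)cc1`, > 402000 nM (a limit of this assay)
compound 3 `N#Cc1ccc(Nc2nccc(NC3CCCCC3)n2)cc1`, 7330 nM
Not yet measured: compound 4 `N#Cc1ccc(Nc2nccc(OC3CCCCC3)n2)cc1`.

Compound 3 gives the lower of the two numbers in this assay; compound 1, which carries a cyclohexyloxy on a different core, gives the higher number. Compound 2 gives only a limit in this assay, > 402000 nM.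

Compound 4 differs from compound 3 by cyclohexyloxy in place of cyclohexylamino on an aromatic carbon. For the measured compounds named here, one measured step bears on the same position: an at least 54-fold lower number from compound 2 to compound 3 (1.73 log units; beyond the scatter), which is large, with the starting value sitting at the limit of > 402000 nM in this assay, at which 1 of the 3 values shown sits. Going by the values given here, that step swapped the sulfur link for the nitrogen link and lowered the number strongly; compound 4 goes the other way, removing the donor but keeping an oxygen acceptor, so a rise is expected, though the only cyclohexyloxy compound measured, compound 1, gives 31200 nM on another core and so guides only loosely.

Compound 4 is therefore expected to give 30000 nM, within 8000 nM to 150000 nM, an expected 4.1-fold higher number from compound 3 to compound 4 (0.61 log units; beyond the scatter). A limit-only result for compound 4 is judged unlikely but not excluded.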

Compound 4, half-maximal cytotoxic concentration: 322000 nM
Beside the measured number, compound 4's estimate is 11-fold (1.03 log units) below it, and the stated range ends below it.
By their numbers in this assay, from the lowest: compound 3; then compound 1; then compound 4. At a limit, above all of these: compound 2.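

In this assay, the change at this position is now seen from the other side: cyclohexyloxy in place of cyclohexylamino on an aromatic carbon gives a 44-fold higher number from compound 3 to compound 4 (1.64 log units; beyond the scatter), which is large, so among the shared-core compounds with numbers, the low value belongs to the cyclohexylamino group, which carries a hydrogen-bond donor where cyclohexyloxy carries none. For the compounds shown here, the methyl on the aromatic carbon also matters, which the earlier compounds could not show: with cyclohexyloxy held constant, a 10-fold higher number from compound 1 to compound 4 (1.01 log units; beyond the scatter), so in this assay a change elsewhere on the core moves the number by a large step as well. Cyclohexyloxy in place of cyclohexylsulfanyl on an aromatic carbon gives an at least 1.2-fold lower number from compound 2 to compound 4 (0.09 log units; that floor lies within the scatter), so this step shows no clear difference between the two compounds. Compound 2 gives a limit and not a number: the limit of > 402000 nM in this assay, at which 1 of the 4 values shown sits.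

Going by these compounds, whether the low number of compound 3 follows the amino hydrogen or the nitrogen link itself stays open, and a cyclohexyl(methyl)amino group or a cyclohexylmethyl group at this position would separate the two. Also open, on these data alone, is whether a methyl on the core of compound 3 would shift the number as it does between compound 1 and compound 4, and whether a smaller chain such as butylamino would behave like cyclohexylamino.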